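The source may hold more compounds than are shown below. What is called first, only, known or untested is meant among the compounds shown, and "the series" means these compounds.

Of the compounds shown here, three with the same general build have been measured in a functional assay on DU-145 cells (Homo sapiens) for antiproliferative activity, read by propidium iodide staining, with a stated time of 96 h (a lower number here means a stronger inhibitor, a higher number a weaker inhibitor), so far. Compound 1 `CC(O)(CSc1cccc(S(F)(F)(F)(F)F)c1)C(=O)Nc1ccc(C#N)c(C(F)(F)F)c1` gives 32700 nM and compound 2 `CC(O)(COc1cccc(S(F)(F)(F)(F)F)c1)C(=O)Nc1ccc(S(F)(F)(F)(F)F)cc1` gives 29600 nM while compound 3 `CC(O)(COc1cccc(S(F)(F)(F)(F)F)c1)C(=O)Nc1ccc(C(F)(F)F)cc1` gives 21000 nM in this assay and sits within the scatter of both others. All three are weak on this scale, and the numbers do not separate them.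

Compound 4 `CC(O)(COc1cccc(C(F)(F)C(F)(F)F)c1)C(=O)Nc1ccc(C(F)(F)F)cc1` is compound 3 with one change a group of 7 heavy atoms (2 carbon, 5 fluorine; no ring) in place of a group of 6 heavy atoms (5 fluorine, 1 sulfur; no ring), on an aromatic carbon in which 1,1,2,2,2-pentafluoroethyl replaces the group of 5 fluorine and 1 sulfur, on an aromatic carbon of a six-membered aromatic ring of carbon only, meta to a large group.

Going by the values given here, no measured step makes this change at this place. The closest evidence is a 1.4-fold lower number from compound 2 to compound 3 (0.15 log units; within the scatter) where the same sulfur-bearing group is replaced by a group of 4 heavy atoms (1 carbon, 3 fluorine; no ring) at another aromatic carbon. That single step stays within the scatter, so it is only a weak guide, yet it gives no reason to expect a real shift in either direction in this assay here.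

The estimated step is a 1.1-fold lower number from compound 3 to compound 4 (0.02 log units; within the scatter) and it is expected to stay within the scatter. For compound 4 the expected value is 20000 nM with an estimated range from 10000 nM to 40000 nM in this measurement.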

Compound 4, half-maximal inhibitory concentration: 7600 nM
Beside the measured number, compound 4's estimate is 2.6-fold (0.42 log units) above it; measured number outside the range, below it.
By their numbers in this assay, from the lowest: compound 4; then compounds 3, 2 and 1 (each within the scatter of the next).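

In this assay, this position gives the first step among these compounds that lies beyond the scatter (a 2.8-fold lower number from compound 3 to compound 4 (0.44 log units; beyond the scatter)), when 1,1,2,2,2-pentafluoroethyl enters on an aromatic carbon of a six-membered aromatic ring of carbon only, meta to a large group. Going by these compounds alone, the only earlier step (a 1.4-fold lower number from compound 2 to compound 3 (0.15 log units; within the scatter)) removed the same group of 5 fluorine and 1 sulfur from another aromatic carbon and stayed within the scatter, so the outcome of removing that group is not the same at both places in these two pairs. Nothing measured here accounts for the change at this position.

A single modest step cannot show whether the number keeps falling as this fluorinated chain changes, so a longer chain such as heptafluoropropyl, or a plain ethyl group with no fluorine, would test how much depends on the chain's length and on its fluorine atoms. From the compounds shown here alone, it also remains open whether pentafluoroethyl gives a similar step when the other ring carries a nitrile, or when a sulfur atom replaces the oxygen in the link to the shared core.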